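The source may hold more compounds than are shown below. What is called first, only, known or untested is meant among the compounds shown, and "the series" means these compounds.

Measured so far in an ADME assay on L6 cells (Rattus norvegicus) for cytotoxicity, read by resazurin assay; a lower number here means a stronger inhibitor, a higher number a weaker inhibitor:
- Compound 1 `N=C(N)c1ccc2[nH]c(Nc3ccc(Cl)cc3)nc2c1`: 41600 nM
- Compound 2 `N=C(N)c1ccc(Nc2nc3cc(C(=N)N)ccc3[nH]2)cc1`: 105000 nM

Of these two compounds, compound 2 has the higher number, at 105000 nM, and so is the weaker inhibitor in this assay. Compound 3 `N=C(N)c1ccc2[nH]c(Nc3ccccc3)nc2c1` has not yet been measured. It differs from compound 2 by one change: a hydrogen atom in place of a group of 3 heavy atoms (1 carbon, 2 nitrogen; no ring), on an aromatic carbon. Going by the values given here, one measured step bears on this, a 2.5-fold higher number from compound 1 to compound 2 (0.40 log units; beyond the scatter), where the same group took the place of one chlorine atom. Among the compounds with values here, compound 3 carries neither that group nor chlorine, and no measured step shows how hydrogen compares with chlorine. Losing the group is therefore expected to reverse part or most of that modest step, giving a lower number. The expected step is a 1.8-fold lower number from compound 2 to compound 3 (0.24 log units; within the scatter). For compound 3 the estimated value is 60000 nM, with an expected range from 27000 nM to 130000 nM.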

Compound 3, half-maximal inhibitory concentration: 237000 nM
Beside the measured number, compound 3's estimate is 4.0-fold (0.60 log units) below it; measured number outside the range, above it.
By their numbers in this assay, from the lowest: compound 1; then compound 2; then compound 3.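

In this assay, the unsubstituted position turns out to carry the highest number of the three, with a 2.3-fold higher number from compound 2 to compound 3 (0.35 log units; beyond the scatter) and a 5.7-fold higher number from compound 1 to compound 3 (0.76 log units; beyond the scatter). At this aromatic carbon, para to a large group, both the chlorine and the group of 3 heavy atoms therefore go with a lower number than hydrogen, and the chlorine goes with the lowest. The earlier step from chlorine to that group showed only a rise in the number, which hid the fact that the group still lies below hydrogen, and nothing available here accounts for either difference.

On these data alone, it remains open whether other groups at this position, such as a methoxy group, an amine or a carboxylic acid, would also give a lower number than hydrogen. Going by these compounds alone, with only three compounds, it is also open whether chlorine's place at the low end would hold among further substituents.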